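The source may hold more compounds than are shown below. What is called first, only, known or untested is meant among the compounds shown, and "the series" means these compounds.

Of the compounds shown here, two of a shared core have been measured in an assay on isolated protein for inhibition of Discoidin domain-containing receptor 2 (Homo sapiens), read by ELISA, with a stated time of 60 min; a higher number here means a weaker inhibitor, a lower number a stronger inhibitor. Compound 1, `Cc1ccc(C(=O)Nc2cccc(C(F)(F)F)c2)cc1-c1ccc2c(-c3ccc(N4CCN(C)CC4)cc3)n[nH]c2c1`, gives 8.8 nM. Compound 2, `Cc1ccc(C(=O)Nc2cccc(C(F)(F)F)c2)cc1-c1ccc2c(-c3cnn(C(C)C)c3)n[nH]c2c1`, gives 7.7 nM. Compound 2 thus has the lower of the two numbers, but the gap to compound 1 is within the usual scatter, so the two cannot be told apart on these data.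

Compound 3, `Cc1ccc(C(=O)Nc2cccc(C(F)(F)F)c2)cc1-c1ccc2c(-c3cnn(C4CCN(C)CC4)c3)n[nH]c2c1`, has not yet been measured. It differs from compound 2 in one place: 1-methylpiperidin-4-yl in place of isopropyl on an aromatic nitrogen. The group that enters brings a six-membered non-aromatic ring with one nitrogen in place of a short three-carbon branch, while the rest of the molecule stays the same.

No single-change step between two measured compounds is available to guide the expectation, and the data give no reason to expect a large shift in either direction. The step from compound 2 to compound 3 is expected to be small, a 1.0-fold higher number from compound 2 to compound 3 (0.02 log units; within the scatter), and no larger than the scatter. Compound 3 is therefore estimated at 8 nM in this assay, with a range from 3 nM to 22 nM.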

Compound 3, half-maximal inhibitory concentration: 3.8 nM
Beside the measured number, compound 3's estimate is 2.1-fold (0.32 log units) above it, within the range that was stated.
By their numbers in this assay, from the lowest: compound 3; then compounds 2 and 1 (each within the scatter of the next).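

In this assay, going by these compounds alone, putting 1-methylpiperidin-4-yl in place of isopropyl on an aromatic nitrogen gives a 2.0-fold lower number from compound 2 to compound 3 (0.31 log units; beyond the scatter), a modest step, but one that lies beyond the scatter and is the first single-place change that can be read in this set. It shows that this position on the five-membered aromatic ring with 2 nitrogen takes a six-membered non-aromatic ring carrying a nitrogen in place of a short three-carbon branch, with no loss of inhibition and a somewhat lower number. Nothing in the data shows why the number falls with this change.

Going by these compounds, the step brings in the ring, the ring nitrogen and its methyl all at once, so the share of each in the lower number stays unknown. A cyclohexyl group, with the ring but no nitrogen, a piperidin-4-yl group without the methyl, and an open chain such as 2-(dimethylamino)ethyl, with the nitrogen but no ring, would each separate these parts at the same position.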